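A Silicon-for-Carbon Swap on the Alkyne Arm

The source may report more compounds than this note shows. Statements on the series, on what has been measured and on what is new or still open speak of the compounds shown alone.

Compound 1, `COC(=O)CC(C)(C)CC(=O)NCC#Cc1ccc2c(c1)C=C([N+](=O)[O-])C(C(F)(F)F)O2`, gives 5900 nM in a functional assay on 1321N1 cells for antagonist activity at P2Y purinoceptor 6 (Homo sapiens), read by fluorescence and calcium flux; on this read-out higher numbers stand for weaker inhibition and lower numbers for stronger inhibition.
Compound 2, `CC[Si](C#Cc1ccc2c(c1)C=C([N+](=O)[O-])C(C(F)(F)F)O2)(CC)CC`, gives 604 nM in this assay.
Compound 3, `CC(C)(C)C#Cc1ccc2c(c1)C=C([N+](=O)[O-])C(C(F)(F)F)O2`, gives 6590 nM in this assay.

Compound 3 has the highest number of the three, but compound 1 sits within the usual scatter of it, so the two cannot be ranked; only compound 2 lies clearly lower. Compound 4, `C[Si](C)(C)C#Cc1ccc2c(c1)C=C([N+](=O)[O-])C(C(F)(F)F)O2`, has not yet been measured. It differs from compound 3 in one place: a group of 4 heavy atoms (3 carbon, 1 silicon; no ring) in place of a group of 4 heavy atoms (4 carbon; no ring), on a triple-bonded carbon. For the measured compounds named here, the one measured step that bears on this change is an 11-fold higher number from compound 2 to compound 3 (1.04 log units; beyond the scatter), in which a silicon-bearing group gave way to the tert-butyl group and the number rose sharply. Compound 4 reverses that direction, bringing a silicon-bearing group back onto the triple-bonded carbon, though one with fewer heavy atoms than the group in compound 2. The number is therefore expected to fall, and a step of a 4.4-fold lower number from compound 3 to compound 4 (0.64 log units; beyond the scatter) is expected, stopping short of a full return to the number seen for compound 2. Compound 4 is estimated at 1500 nM, with a range from 500 nM to 5000 nM.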

Compound 4, half-maximal inhibitory concentration: 785 nM
Estimate against measurement, compound 4: 1.9-fold (0.28 log units) above; measured number inside the range.
By their numbers in this assay, from the lowest: compounds 2 and 4 (each within the scatter of the next); then compounds 1 and 3 (each within the scatter of the next).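

Compound 3 and compound 4 carry groups with the same count of heavy atoms, so the exchange of one carbon for one silicon on the triple-bonded carbon stands alone here and gives an 8.4-fold lower number from compound 3 to compound 4 (0.92 log units; beyond the scatter), which is beyond the scatter. For the compounds shown here, the silicon-bearing group in compound 4 also holds fewer heavy atoms than the one in compound 2, yet a 1.3-fold higher number from compound 2 to compound 4 (0.11 log units; within the scatter) lies within the scatter, so in this pair the smaller group cannot be told apart from the larger one. No measurement here explains why silicon matters at this position.

The compounds shown leave open whether silicon itself is needed or whether another group could match it on the triple-bonded carbon. A longer chain ending in an amine or a carboxylic acid would test how much this position tolerates.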